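Replacing a Pyrimidine with Chlorine on a Shared Core

A few compounds are considered here, and "the series" means these few. Any claim that something is new, unique, unknown or untested is made for them only; others in the source may bear on it.

Compound 1 `CC(C)(C)c1cc(NC(=O)Nc2cccc(Oc3cncc(-c4cncnc4)n3)c2)on1`: 79.4%
Compound 2 `Nc1ccc(-c2cncc(-c3cncnc3)n2)cc1`: 77%

In an assay on isolated protein for inhibition of high affinity nerve growth factor receptor (Homo sapiens), with a stated time of 60 min, tested at 20 uM (a lower number here means less inhibition, a higher number more inhibition at the concentration tested (going by the name of the read-out)), compound 1 gives 79.4% and compound 2 gives 77%. Compound 2 holds the lower of the two numbers, yet the gap to compound 1 lies within the scatter, so the two cannot be separated. Compound 3 `Nc1ccc(-c2cncc(Cl)n2)cc1` differs from compound 2 by chloro in place of pyrimidin-5-yl on an aromatic carbon. Among the measured compounds shown here, no step between two measured compounds is known here, so the effect of this change rests on expectation alone: inhibition is expected to fall, with a step of a number 32 percentage points lower from compound 2 to compound 3 (beyond the scatter) beyond the scatter. Compound 3 is estimated at 45%, between 15% and 75%.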

Compound 3, a percentage reported as inhibition, at one concentration (the size of the read-out at that concentration, not a potency): 47%
Compound 3: the middle estimate sits 2 percentage points below what was measured, and the stated range covers the measured number.
By their numbers in this assay, from the lowest: compound 3; then compounds 2 and 1 (each within the scatter of the next).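

In this assay, among the compounds shown here, putting chloro in place of pyrimidin-5-yl gives a number 30 percentage points lower from compound 2 to compound 3 (beyond the scatter) and is the first single change that can be read at this position. What sits on this aromatic carbon therefore matters, yet inhibition does not vanish with chloro there, as compound 3 still gives 47% at the concentration tested. Nothing measured here explains the size of this step. Going by these compounds, whether an amine or a methoxy group at this position would keep inhibition nearer that of compound 2 remains open. So does whether another ring, such as pyridin-3-yl, could replace the pyrimidine.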